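The compounds below may be only part of what the source reports. "The series", "measured", "known", "first", "only" and "open" are said of these compounds alone.

Compound 1 `CCc1cc2ccccc2nc1-c1cc(-c2ccccc2)no1` and compound 2 `CCc1cc2ccccc2nc1-c1cc(-c2ccc(F)cc2)no1` share one core and differ only in a single substituent. In a functional assay on MDA-MB-231 cells (Homo sapiens) for inhibition, read by MTT assay, with a stated time of 24 h (a higher number here means a weaker inhibitor, a lower number a stronger inhibitor), compound 1 gives only a limit of the assay, > 100000 nM. In this assay compound 2 likewise gives only a limit, > 100000 nM. The step that the two limits leave unreadable from compound 1 to compound 2 therefore cannot be read, since both values sit at the limit of > 100000 nM in this assay, at which 2 of the 2 values shown sit. Compound 3 `CCCCc1cc2ccccc2nc1-c1cc(-c2ccc(F)cc2)no1` differs from compound 2 by ethyl in place of hydrogen on a saturated chain carbon, two bonds along the chain from an aromatic carbon. Among the compounds with values here, no measured step bears on this change: the only measured step is unreadable, so the numbers so far indicate neither a direction nor a size in this assay. Compound 2 itself stands only at a limit. Compound 3 is accordingly expected to remain near that limit, with an estimated step of a number no higher from compound 2 to compound 3 (the limit leaves the size open) and an estimated value of 100000 nM, in a range from 30000 nM to 300000 nM.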

Compound 3, half-maximal inhibitory concentration: 24200 nM
For compound 3 the middle estimate is 4.1-fold (0.62 log units) above the measured one; the measured number lies below the stated range.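

In this assay, the chain position yields the first readable step among these compounds: ethyl in place of hydrogen on a saturated chain carbon, two bonds along the chain from an aromatic carbon, gives an at least 4.1-fold lower number from compound 2 to compound 3 (0.61 log units; beyond the scatter). Within the data shown here, the earlier change, fluoro in place of hydrogen on an aromatic carbon, could not be read, so this is the first sign that the number responds to a change in the structure. The full size of the step stays open, since compound 2 stands at a limit and the step is a bound rather than a measured distance: the limit of > 100000 nM in this assay, at which 2 of the 3 values shown sit.

On these data alone, whether a longer chain, or an amine or a carboxylic acid at the end of the butyl chain, would lower the number further remains open. As far as these compounds go, whether fluoro in place of hydrogen on an aromatic carbon has a readable effect alongside the butyl chain also remains open.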